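A few compounds are considered here, and "the series" means these few. Any claim that something is new, unique, unknown or untested is made for them only; others in the source may bear on it.

Compound 1, `CCOC(=O)CCO/N=C(/c1ccc(OC)c(OC)c1OC)c1cccc2ccccc12`, was run in a functional assay on THP-1 cells (Homo sapiens) for inhibition, read by sulforhodamine B assay, with a stated time of 48 h; on this read-out lower numbers stand for stronger inhibition and higher numbers for weaker inhibition. In this assay compound 1 gives > 20000 nM, which is a limit of the assay and not a number. On the values shown, compound 1 stands at the limit of > 20000 nM in this assay, at which 1 of the 2 values shown sits, so only a range is known for it. The other measured compound is compound 2, `COc1ccc(C(c2ccc(OC(C)CN(C)C)cc2)c2cccc3ccccc23)c(OC)c1OC`, and in this assay compound 2 gives 15000 nM. No single change links compound 1 and compound 2, so their two values simply stand side by side.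

Compound 3, `CCOC(=O)/C=C/CO/N=C(/c1ccc(OC)c(OC)c1OC)c1cccc2ccccc12`, has not yet been measured. It differs from compound 1 in one place: 2-(ethoxycarbonyl)ethenyl in place of (ethoxycarbonyl)methyl on a saturated chain carbon bound to an oxygen on an unsaturated carbon. The (ethoxycarbonyl)methyl leaves and the 2-(ethoxycarbonyl)ethenyl enters, on a saturated chain carbon bound to an oxygen on an unsaturated carbon. No measured step of this kind exists among the compounds shown, so the size of the step rests on expectation alone. The step from compound 1 to compound 3 is expected to be a step that the limit leaves unreadable from compound 1 to compound 3, which is none beyond the scatter. Compound 3 is therefore estimated to give 25000 nM, within a range from 8000 nM to 80000 nM, in this assay.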

Compound 3, half-maximal inhibitory concentration: > 20000 nM
Compound 3: only a limit was reported; the forecaster's own chance of this, stated with the estimate: 70%; the middle value is on the limit's open side.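

Compound 1 and compound 3 both stand only at a limit in this assay and not at a number, so the step between them cannot be read: the limit of > 20000 nM in this assay, at which 2 of the 3 values shown sit.

The compounds shown leave open whether 2-(ethoxycarbonyl)ethenyl or (ethoxycarbonyl)methyl gives the stronger inhibition, and how far past the limit either compound lies.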